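Fluorine position in the acid chain of compound 3

This account rests on a few compounds, and the source may have more. Where it says the series, first, only, none or still open, it means among the compounds named here.

Measured so far in a functional assay on CHO cells for agonist activity at Free fatty acid receptor 1 (Homo sapiens), read by calcium flux; on this read-out lower numbers stand for an effect already at smaller amounts and higher numbers for an effect only at larger amounts of compound:
- compound 1, `Cc1cccc(C)c1-c1cccc(COc2ccc(CCC(=O)O)nc2)c1`: 71 nM
- compound 2, `Cc1cccc(C)c1-c1cccc(COc2ccc(CCC(=O)O)s2)c1`: 52 nM
- compound 3, `Cc1cccc(C)c1-c1cccc(COc2ccc(CC(F)C(=O)O)cn2)c1`: 8.6 nM

Compound 3 holds the lowest number of the three in this assay. Its nearest neighbour is compound 2; the gap between them is beyond the scatter, as is the larger gap to compound 1. The three compounds differ from one another in more than one place, so no single change can be read from these pairs; compound 3 simply stands apart from the other two on the numbers.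

Compound 4, `Cc1cccc(C)c1-c1cccc(COc2ccc(C(F)CC(=O)O)cn2)c1`, keeps every atom of compound 3 and only rearranges the acid chain: 2-carboxy-1-fluoroethyl in place of 2-carboxy-2-fluoroethyl on an aromatic carbon. The carboxylic acid and the fluorine remain on the same three-carbon chain, with the fluorine moved by one position.

Among the measured compounds shown here, no measured pair in this set shows what such a rearrangement does in this assay, so the expected step rests on the change itself. A small step toward higher numbers, at the edge of the scatter, is expected from compound 3 to compound 4, a 2.3-fold higher number from compound 3 to compound 4 (0.37 log units; beyond the scatter), with a wide range in either direction. Compound 4 is estimated at 20 nM, between 5 nM and 80 nM.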

Compound 4, half-maximal effective concentration in the Free fatty acid receptor 1 assay: 18 nM
Beside the measured number, compound 4's estimate is 1.1-fold (0.05 log units) above it; measured number inside the range.
By their numbers in the Free fatty acid receptor 1 assay, from the lowest: compound 3; then compound 4; then compounds 2 and 1 (each within the scatter of the next).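

Among the compounds shown here, in the Free fatty acid receptor 1 assay compound 3 gives 8.6 nM and compound 4 gives 18 nM in the first comparison that differs in one place only. With the same atoms joined differently, 2-carboxy-1-fluoroethyl in place of 2-carboxy-2-fluoroethyl on an aromatic carbon two atoms from the ring nitrogen gives in the Free fatty acid receptor 1 assay a 2.1-fold higher number from compound 3 to compound 4 (0.32 log units; beyond the scatter), a modest step that lies beyond the scatter. The acid chain at this position therefore responds to where the fluorine sits, though only by a modest amount, and nothing at hand bears on why the number moves in this direction.

Open, as far as these compounds go, is what the fluorine contributes at either chain position, a question that a methyl or hydroxyl group in its place, a second fluorine on the same chain, or a longer chain carrying the acid on the same core could address. From the compounds shown here alone, in a physicochemical assay for lipophilicity, at pH 7.4 (a higher number here means a more lipophilic compound, a lower number a more polar compound), compound 3 gives "not determined" (no result reported) and compound 4 gives "not determined" (no result reported) and so the step from compound 3 to compound 4 cannot be read there, and whether the rearrangement shifts that read-out also stays open.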